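A few compounds are considered here, and "the series" means these few. Any claim that something is new, unique, unknown or untested is made for them only; others in the source may bear on it.

Working notes on the series. In an assay on isolated protein for inhibition of Amine oxidase [flavin-containing] B (Homo sapiens), read by Amplex Red (on this read-out lower numbers stand for stronger inhibition and higher numbers for weaker inhibition), compound 1 `NC/C=C(/F)COc1ccc(Oc2ccccc2)cc1` gives 450 nM, while compound 2 `CC(C)(C)c1ccc(OC/C(F)=C\CN)cc1` gives 6400 nM, the highest of the two numbers in this assay and well beyond the scatter from compound 1. Compound 3 `NC/C=C(/F)COc1ccc(OC(F)(F)F)cc1` is not yet measured; relative to compound 2 the change is trifluoromethoxy in place of tert-butyl on an aromatic carbon. Among the compounds with values here, no step between measured compounds covers this change. With compound 2 at 6400 nM and compound 1 at 450 nM setting the range seen so far, a moderate step toward a lower number is expected, a 3.2-fold lower number from compound 2 to compound 3 (0.51 log units; beyond the scatter). For compound 3 the estimate in this assay is 2000 nM, ranging from 500 nM to 8000 nM.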

Compound 3, half-maximal inhibitory concentration: 70 nM
Compound 3: the middle estimate sits 29-fold (1.46 log units) above what was measured, outside the stated range (below it).
By their numbers in this assay, from the lowest: compound 3; then compound 1; then compound 2.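

In this assay, trifluoromethoxy in place of tert-butyl gives a 91-fold lower number from compound 2 to compound 3 (1.96 log units; beyond the scatter), showing that this position responds far more strongly to the choice of group than compounds 1 and 2 suggested. Trifluoromethyl in place of phenyl on the oxygen gives a 6.4-fold lower number from compound 1 to compound 3 (0.81 log units; beyond the scatter), so phenyl on that oxygen is not required for a low number here. Nothing available explains either step. The compounds shown leave open how much of the step rests on the oxygen and how much on the fluorines. Methoxy and trifluoromethyl directly on the aromatic carbon would separate the two.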